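This account rests on a few compounds, and the source may have more. Where it says the series, first, only, none or still open, it means among the compounds named here.

Compound 1 `CC#C[C@H]1CN(S(=O)(=O)c2ccc(N)nc2)CCN1c1ccc(S(=O)(=O)NC)cn1` gives 381 nM in an assay on cells (Hepatocyte) for inhibition of glucokinase regulatory protein (Mus musculus), with stated times of 20 min and 40 min; on this read-out higher numbers stand for an effect only at larger amounts of compound and lower numbers for an effect already at smaller amounts.
Compound 2 `CC#C[C@H]1CN(S(=O)(=O)c2ccc(N)nc2)CCN1c1ccc(C(C)(O)C(F)(F)F)nc1` gives 1450 nM.
Compound 3 `CC#C[C@H]1CN(S(=O)(=O)c2ccc(N)nc2)CCN1c1ccc(C(O)(COC)C(F)(F)F)cc1` gives 202 nM.

Among these three, compound 3 has the lowest number in this assay. Its nearest neighbour is compound 1, whose number is higher only by a margin that stays within the usual scatter, so the two cannot be told apart on this evidence. Compound 2 stands much further off, beyond the scatter.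

Compound 4 `CC#C[C@H]1CN(S(=O)(=O)c2ccc(N)nc2)CCN1c1ccc(C(O)(CC#N)C(F)(F)F)cc1` has not yet been measured. It differs from compound 3 in one place: cyano in place of methoxy on a saturated chain carbon, two bonds along the chain from an aromatic carbon and an oxygen on a saturated carbon. Seen one bond further out, the same change reads methoxymethyl to cyanomethyl. Among the compounds with values here, no measured pair shows this change, so the data give no direct guide to its effect. With nothing to point either way, no step beyond the scatter is expected in this assay in either direction. The expected step from compound 3 to compound 4 is a 1.2-fold higher number from compound 3 to compound 4 (0.09 log units; within the scatter). Compound 4 is therefore estimated at 250 nM, with a likely range from 100 nM to 700 nM.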

Compound 4, half-maximal effective concentration: 219 nM
For compound 4 the middle estimate is 1.1-fold (0.06 log units) above the measured one, and the stated range covers the measured number.
By their numbers in this assay, from the lowest: compounds 3, 4 and 1 (each within the scatter of the next); then compound 2.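

In this assay, replacing methoxy with cyano on this saturated chain carbon gives a 1.1-fold higher number from compound 3 to compound 4 (0.04 log units; within the scatter), so the two compounds cannot be told apart. Within the data shown here, this is the first pair here that differs in only one place, and it shows that at this position the read-out stays within the scatter when methoxymethyl becomes cyanomethyl. Methoxy and cyano match in heavy atoms and hydrogen-bond acceptors, but cyano brings a triple bond, and no measurement here explains why the exchange leaves the number within the scatter.

On these data alone, one pair gives no trend, so how far this position tolerates change remains open. An amine, a carboxylic acid or a longer chain in the same place could give a clearly different number, and the compounds shown cannot say which way it would go.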